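Adding a Hydroxy Group to a Nitrophenyl Urea

This account rests on a few compounds, and the source may have more. Where it says the series, first, only, none or still open, it means among the compounds named here.

Measured compounds:
compound 1 `CN(C)C(=O)N(Cc1cccc([N+](=O)[O-])c1)Cc1ccco1`: 23800 nM
compound 2 `CCOC(=O)N1CCC(N(Cc2cc(Cl)ccc2O)C(=O)N(C)C)CC1`: 25700 nM
compound 3 `CCOC(=O)N1CCC(N(Cc2ccc([N+](=O)[O-])cc2)C(=O)N(C)C)CC1`: 16400 nM

All three were tested in a functional assay on KB cells (Homo sapiens) for antiproliferative activity, read by MTT assay, with a stated time of 48 h; on this read-out higher numbers stand for weaker inhibition and lower numbers for stronger inhibition. On these numbers compound 1 stands second highest of the three; its nearest neighbour is compound 2, and its furthest is compound 3, and both of those gaps lie within the scatter of repeated measurements, so the three cannot be told apart.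

Compound 4 `CN(C)C(=O)N(Cc1ccco1)Cc1cc([N+](=O)[O-])ccc1O` differs from compound 1 by a single change: hydroxy in place of hydrogen on an aromatic carbon. Among the measured compounds shown here, only one measured step exists in this set, a 1.6-fold lower number from compound 2 to compound 3 (0.20 log units; within the scatter), and it exchanges one aryl ring for another rather than adding a hydroxy group, so it gives no direct guide; it does show that even a whole-ring swap stayed within the scatter here. For the measured compounds named here, no measured pair separates a hydroxy from a hydrogen on this ring. A step within the scatter is therefore the reasonable expectation, in no particular direction.

Compound 4 is expected to give about 24000 nM, with a likely range from 9000 nM to 60000 nM. The expected step, a 1.0-fold higher number from compound 1 to compound 4 (0.00 log units; within the scatter), is estimated to be no larger than the usual scatter.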

Compound 4, half-maximal inhibitory concentration: 20800 nM
Compound 4: the middle estimate sits 1.2-fold (0.06 log units) above what was measured; the range from low to high includes it.
By their numbers in this assay, from the lowest: compounds 3, 4, 1 and 2 (each within the scatter of the next).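

In this assay, the change gives a 1.1-fold lower number from compound 1 to compound 4 (0.06 log units; within the scatter) and no more than that, so compound 1 and compound 4 cannot be told apart. Among the compounds shown here, this is the first direct reading of a hydroxy against a hydrogen in this set, on an aromatic carbon ortho to a large group and para to a nitro group, and it shows that this single added oxygen leaves the read-out within the scatter on the core of compound 1. Nothing measured here offers an explanation for this result.

As far as these compounds go, whether a larger or different group at this carbon, such as an amine, a methoxy group or a carboxylic acid, would move the number beyond the scatter remains open. One carbon on one core also cannot show whether a hydroxy behaves the same way elsewhere.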